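Swapping isopropyl for propargyl on the most active compound

The source may report more compounds than this note shows. Statements on the series, on what has been measured and on what is new or still open speak of the compounds shown alone.

Values in a functional assay on the whole organism for inhibition, with Scenedesmus acutus as the target (on this read-out higher numbers stand for weaker inhibition and lower numbers for stronger inhibition), for the compounds measured so far
compound 1 `S=c1s/c(=N\c2ccc(Br)cc2)n2n1CCCC2` gives 162 nM
compound 2 `CC(C)Oc1cc(/N=c2\sc(=S)n3n2CCCC3)c(F)cc1Cl` gives 13.8 nM
compound 3 `S=c1n(-c2ccc(Br)cc2)c(=S)n2n1CCCC2` gives 64.6 nM

Of these three, compound 2 has the lowest number and so shows the strongest inhibition in this assay of the set. Compound 3 is its nearest neighbour and compound 1 its furthest, and both gaps lie beyond the usual scatter of repeated measurements.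

The next compound to be tested, compound 4 `C#CCOc1cc(/N=c2\sc(=S)n3n2CCCC3)c(F)cc1Cl`, differs from compound 2 in one place only. It carries propargyl in place of isopropyl on an oxygen on an aromatic ring. The same difference, cut one bond further out, reads isopropoxy to propargyloxy.

For the measured compounds named here, no measured pair in this set differs in one place, so the data give no direct guide to the size of this exchange. The expectation therefore rests on compound 2 (13.8 nM) as its starting point. The expected step (a 1.2-fold lower number from compound 2 to compound 4 (0.06 log units; within the scatter)) is estimated to stay within the scatter, with no firm direction. For compound 4 the estimated value is 12 nM (expected range 4 nM to 36 nM).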

Compound 4, half-maximal inhibitory concentration: 7.24 nM
Estimate against measurement, compound 4: 1.7-fold (0.22 log units) above; low and high end bracket the measured number.
By their numbers in this assay, from the lowest: compounds 4 and 2 (each within the scatter of the next); then compound 3; then compound 1.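

In this assay the exchange of isopropyl for propargyl on an oxygen on an aromatic ring gives a 1.9-fold lower number from compound 2 to compound 4 (0.28 log units; within the scatter) and so leaves compound 2 and compound 4 indistinguishable on this read-out. For the compounds shown here, this is the first comparison in the set between compounds that differ in one place, and it shows that, with the rest of the structure held constant, this position takes a group with a triple bond outside aromatic rings in place of isopropyl, at the same count of heavy atoms, with no step beyond the scatter. Nothing available here accounts for the two groups reading alike.

The compounds shown carry only these two groups on that oxygen, so it remains open whether a longer chain such as butyl, a benzyl group or a carboxylic acid there would also stay within the scatter of compound 2. From the compounds shown here alone, the chlorine and fluorine on the ring are the same in both compounds, so it also remains open whether this exchange would give a similar step with hydrogen in place of either halogen.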